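A Tertiary Thienylmethyl Amine Variant of Compound 2

A few compounds are considered here, and "the series" means these few. Any claim that something is new, unique, unknown or untested is made for them only; others in the source may bear on it.

Three measured compounds share one core and differ only in the amine that sits on a saturated ring carbon. Compound 1 `COC[C@H](NC1CCN(CCCc2c[nH]c3ccc(Cn4cncn4)cc23)CC1)c1ccc(F)cc1`, compound 2 `C[C@@H](NC1CCN(CCCc2c[nH]c3ccc(-n4cnnc4)cc23)CC1)c1ccccc1` and compound 3 `NC(=O)OC[C@H](NC1CCN(CCCc2c[nH]c3ccc(-n4cnnc4)cc23)CC1)c1ccccc1` have all been tested in an assay on CHO cells for agonist activity at 5-hydroxytryptamine receptor 1D (Homo sapiens), read by GTPgammaS binding (on this read-out lower numbers stand for an effect already at smaller amounts and higher numbers for an effect only at larger amounts of compound), where compound 1 gives 8.9 nM, compound 2 gives 13 nM and compound 3 gives 9.3 nM. Compound 2 sits at one end of these three numbers, but its distance to compound 3 and to compound 1 both lie within the scatter, so the three compounds cannot be told apart on this read-out. Going by the values given here, the only single-point step among them, a 1.4-fold lower number from compound 2 to compound 3 (0.15 log units; within the scatter), shows that a 2-(carbamoyloxy)-1-phenylethyl group is accepted as well as the 1-phenylethyl group.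

Compound 4 `CN(Cc1cccs1)C1CCN(CCCc2c[nH]c3ccc(-n4cnnc4)cc23)CC1` is not yet measured. It differs from compound 2 in one place: methyl((thiophen-2-yl)methyl)amino in place of (1-phenylethyl)amino on a saturated ring carbon. Among the compounds with values here, no measured step removes the hydrogen-bond donor from this amine nitrogen or exchanges the six-membered aromatic ring for a five-membered one with a sulfur atom, so the data give no direct guide; the step from compound 2 to compound 3 only shows that the group on this nitrogen tolerates some variation. Compound 4 is therefore expected to show a modest step, a 1.5-fold higher number from compound 2 to compound 4 (0.19 log units; within the scatter), with wide uncertainty, giving an estimated 20 nM in the range 5 nM to 80 nM.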

Compound 4, half-maximal effective concentration: 3.5 nM
Compound 4: middle estimate off by 5.7-fold (0.76 log units), on the high side; measured number below the stated range.
By their numbers in this assay, from the lowest: compound 4; then compounds 1, 3 and 2 (each within the scatter of the next).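

In this assay, methyl((thiophen-2-yl)methyl)amino in place of (1-phenylethyl)amino on the saturated ring carbon gives a 3.7-fold lower number from compound 2 to compound 4 (0.57 log units; beyond the scatter), the only step among these compounds that lies beyond the scatter. This position therefore does more than accept variation: a group with no hydrogen-bond donor, a five-membered aromatic ring with one sulfur atom and no defined stereocentre goes with a lower number than the group it replaces. Nothing available here explains this step.

The change alters the hydrogen-bond donor count, the aromatic ring, the methyl group on nitrogen and the stereocentre all at once, so the compounds shown cannot assign the step to any one of these features. Open comparisons include methyl(benzyl)amino, which would keep the six-membered aromatic ring of carbon only on a comparable tertiary amine, and ((thiophen-2-yl)methyl)amino, which would keep the sulfur ring on an amine nitrogen that still bears its hydrogen.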